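The compounds below may be only part of what the source reports. "The series", "measured", "known", "first", "only" and "open" are said of these compounds alone.

Measured so far in a functional assay on SW-620 cells (Homo sapiens) for inhibition, read by sulforhodamine B assay, with a stated time of 48 h; on this read-out lower numbers stand for stronger inhibition of growth and higher numbers for weaker inhibition of growth: compound 1 `COc1cc(-c2cc(/C=C/C(=O)c3ccc(N)cc3)[nH]n2)cc(OC)c1OC` gives 2050 nM; compound 2 `COc1ccc(C(=O)/C=C/c2cc(-c3cc(OC)c(OC)c(OC)c3)n[nH]2)cc1` gives 1620 nM. The two stand together within the scatter, as seen in the step of a 1.3-fold lower number from compound 1 to compound 2 (0.10 log units; within the scatter), methoxy in place of amino on an aromatic carbon.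

Compound 3 `COc1cc(-c2cc(/C=C/C(=O)c3ccc(F)c(F)c3)[nH]n2)cc(OC)c1OC` is not yet measured. It differs from compound 2 by 3,4-difluorophenyl in place of 4-methoxyphenyl on a carbonyl carbon. Among the measured compounds shown here, the only measured step, from compound 1 to compound 2, also exchanges the substituent of that same aryl ketone and stayed within the scatter, so for compound 3 no step beyond the scatter is expected in this assay, a 1.1-fold lower number from compound 2 to compound 3 (0.03 log units; within the scatter). Compound 3 is estimated at 1500 nM, range 600 nM to 4000 nM.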

Compound 3, concentration for 50% growth inhibition: 3420 nM
Compound 3: middle estimate off by 2.3-fold (0.36 log units), on the low side, within the range that was stated.
By their numbers in this assay, from the lowest: compounds 2, 1 and 3 (each within the scatter of the next, the first and the last beyond it).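

In this assay the group on the carbonyl carbon now gives a modest step beyond the scatter, a 2.1-fold higher number from compound 2 to compound 3 (0.32 log units; beyond the scatter) with 3,4-difluorophenyl in place of 4-methoxyphenyl. The same group in place of 4-aminophenyl stays within the scatter, a 1.7-fold higher number from compound 1 to compound 3 (0.22 log units; within the scatter) so the position separates only compound 2 and compound 3. Nothing available accounts for this difference.

Where a 4-hydroxyphenyl or 4-chlorophenyl group would fall at this position remains open. So does the effect of any change elsewhere on the shared core.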